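The source may report more compounds than this note shows. Statements on the series, on what has been measured and on what is new or still open speak of the compounds shown alone.

The measured compounds and their values:

Compound 1, `COc1ccc2nc(C)cc(NCc3ccccc3)c2c1`, gives 28600 nM in a functional assay on MCF-10A cells (Homo sapiens) for antiproliferative activity, with a stated time of 48 h; a lower number here means that less compound is needed, a higher number that more compound is needed for the effect.
Compound 2, `COc1ccc2nc(C)cc(NCc3cccc(F)c3)c2c1`, gives 14700 nM in this assay.
Compound 3, `COc1ccc(CNc2cc(C)nc3ccc(OC)cc23)cc1`, gives 9700 nM in this assay.

The three measured compounds share a core and differ only in what sits on the pendant phenyl ring. From compound 1 to compound 2 the change is fluoro in place of hydrogen on an aromatic carbon, and it produced a 1.9-fold lower number from compound 1 to compound 2 (0.29 log units; within the scatter). From compound 1 to compound 3 the change is methoxy in place of hydrogen on an aromatic carbon, which gave a 2.9-fold lower number from compound 1 to compound 3 (0.47 log units; beyond the scatter). Compound 3 has the lowest number of the three, but its gap to compound 2 is within the scatter, so no order between these two can be read from the numbers.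

Compound 4, `COc1ccc2nc(C)cc(NCc3ccc(OC)c(F)c3)c2c1`, is not yet measured. It differs from compound 3 by fluoro in place of hydrogen on an aromatic carbon. Going by the values given here, this is the same kind of change as the one from compound 1 to compound 2, though not the same: in compound 2 the fluoro sits meta to a large group, while in compound 4 it sits ortho to a methoxy group and meta to a large group. Among the compounds with values here, only one example of the change exists among the measured compounds, so the expectation for compound 4 rests on that single step. Alongside a 1.9-fold lower number from compound 1 to compound 2 (0.29 log units; within the scatter), the step from compound 3 to compound 4 in this assay is expected to be a 1.8-fold lower number from compound 3 to compound 4 (0.25 log units; within the scatter), a step of similar size. Compound 4 is therefore estimated at 5500 nM, with a range from 2500 nM to 12000 nM.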

Compound 4, half-maximal effective concentration: 10300 nM
For compound 4 the middle estimate is 1.9-fold (0.27 log units) below the measured one; the range from low to high includes it.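

In this assay, fluoro in place of hydrogen, here ortho to a methoxy group and meta to a large group, gave a 1.1-fold higher number from compound 3 to compound 4 (0.03 log units; within the scatter), and the gap between this step and the one on the core without the methoxy group stays small enough that the two steps cannot be told apart: the same change on two cores in this assay, a 1.9-fold lower number (0.29 log units; within the scatter) from compound 1 to compound 2 and a 1.1-fold higher number (0.03 log units; within the scatter) from compound 3 to compound 4, 2.1-fold (0.32 log units) apart, within the scatter of two such steps. Methoxy in place of hydrogen gave a 1.4-fold lower number from compound 2 to compound 4 (0.15 log units; within the scatter), and this step also cannot be told apart from its counterpart on the core without the fluoro group: the same change on two cores in this assay, a 2.9-fold lower number (0.47 log units; beyond the scatter) from compound 1 to compound 3 and a 1.4-fold lower number (0.15 log units; within the scatter) from compound 2 to compound 4, 2.1-fold (0.32 log units) apart, within the scatter of two such steps. Going by these compounds alone, the two changes are therefore compatible with carrying over from one core to the other, but this does not show that they do, as each change has only two examples and, of the four steps, only the one from compound 1 to compound 3 lies beyond the scatter.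

The compounds shown leave open whether a group of another kind on the pendant phenyl ring, such as an amine, a carboxylic acid or a longer alkoxy chain, would give a step that clearly stands out from the scatter. They also leave open whether any of these steps would hold with a different group in place of the methyl or methoxy group on the shared core.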